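The source may hold more compounds than are shown below. What is called first, only, known or untested is meant among the compounds shown, and "the series" means these compounds.

Three sulfonamides sharing one core have been tested so far. In a functional assay on HeLa cells (Homo sapiens) for cytotoxicity, read by sulforhodamine B assay (a lower number here means a stronger inhibitor, a higher number a weaker inhibitor), compound 1 (`Cc1ccc(S(=O)(=O)NC(C2=CC(=O)c3c(O)ccc(O)c3C2=O)C(C)C)cc1`) gives 4850 nM, compound 2 (`COc1ccc(S(=O)(=O)NC(C2=CC(=O)c3c(O)ccc(O)c3C2=O)C(C)C)cc1`) gives 8950 nM and compound 3 (`CC(C)C(NS(=O)(=O)c1ccc(Cl)cc1)C1=CC(=O)c2c(O)ccc(O)c2C1=O`) gives 8650 nM. Compound 3 thus sits level with compound 2, and its gap to compound 1 also stays within the scatter, so no order can be drawn among the three.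

The next compound, compound 4 (`CC(C)C(NS(=O)(=O)c1cccc(Br)c1)C1=CC(=O)c2c(O)ccc(O)c2C1=O`), carries 3-bromophenyl in place of 4-chlorophenyl on a sulfonyl sulfur. For the measured compounds named here, no tested compound carries a 3-bromophenyl group, so the data hold no direct measure of this exchange.

The nearest evidence comes from the changes on an aromatic carbon. Methoxy in place of methyl gives a 1.8-fold higher number from compound 1 to compound 2 (0.27 log units; within the scatter), chloro in place of methyl gives a 1.8-fold higher number from compound 1 to compound 3 (0.25 log units; within the scatter), and chloro in place of methoxy gives a 1.0-fold lower number from compound 2 to compound 3 (0.01 log units; within the scatter). All three steps are small and lie within the scatter, so in this assay no shift beyond the scatter is expected, in either direction. The expected change is a 1.2-fold lower number from compound 3 to compound 4 (0.06 log units; within the scatter). For compound 4 the estimated value is 7500 nM, with an expected range from 3500 nM to 16000 nM.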

Compound 4, half-maximal inhibitory concentration: 860 nM
For compound 4 the middle estimate is 8.7-fold (0.94 log units) above the measured one; measured number below the stated range.
By their numbers in this assay, from the lowest: compound 4; then compounds 1, 3 and 2 (each within the scatter of the next).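

At this position on the sulfonyl sulfur, the aryl group can clearly move the number in this assay: 3-bromophenyl in place of 4-chlorophenyl gives a 10-fold lower number from compound 3 to compound 4 (1.00 log units; beyond the scatter) and the same group gives a 10-fold lower number from compound 2 to compound 4 (1.02 log units; beyond the scatter) in place of 4-methoxyphenyl and a 5.6-fold lower number from compound 1 to compound 4 (0.75 log units; beyond the scatter) in place of 4-methylphenyl. Compound 4 is therefore the strongest inhibitor of the four, while compound 1, compound 2 and compound 3 remain within the scatter of one another, so the flat picture given by those three does not extend to 3-bromophenyl. The data include no measurement that bears on why this exchange has so large an effect.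

Compound 4 differs from the others in both the halogen and its place on the ring, so the compounds shown cannot tell which of the two goes with the step. Going by these compounds, how an unsubstituted phenyl, or a phenyl ring carrying an amine or a carboxylic acid, would compare on the same sulfonyl sulfur also remains open.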